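Removing a Methoxy Group: From Compound 2 to Compound 3

The compounds below may be only part of what the source reports. "The series", "measured", "known", "first", "only" and "open" are said of these compounds alone.

Of the compounds shown here, two have been measured in a functional assay on HEp-2 cells (Homo sapiens) for antiproliferative activity, read by MTT assay, with a stated time of 72 h; on this read-out higher numbers stand for weaker inhibition and lower numbers for stronger inhibition. Compound 1 `O=c1cc(CSC(=S)N2CCCCC2)oc2ccccc12` gives 12000 nM in this assay. Compound 2 `COc1ccc2oc(CSC(=S)N(C(C)C)C(C)C)cc(=O)c2c1` gives 7600 nM in this assay. Compound 2 holds the lowest of the two numbers, yet the gap to compound 1 lies within the scatter, so no order can be read between them.

Compound 3 `CC(C)N(C(=S)SCc1cc(=O)c2ccccc2o1)C(C)C` is the next compound to be measured in this assay. It differs from compound 2 in one place: hydrogen in place of methoxy on an aromatic carbon. Going by the values given here, no pair of measured compounds shows the effect of such a change, and the two numbers in hand are close to each other, so there is nothing to suggest a step beyond the scatter in either direction. The expected step from compound 2 to compound 3 is therefore a 1.2-fold higher number from compound 2 to compound 3 (0.07 log units; within the scatter). Compound 3 is estimated to give 9000 nM in this assay, with a range from 4000 nM to 20000 nM.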

Compound 3, half-maximal inhibitory concentration: 13600 nM
Estimate against measurement, compound 3: 1.5-fold (0.18 log units) below; measured number inside the range.
By their numbers in this assay, from the lowest: compounds 2, 1 and 3 (each within the scatter of the next).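

With hydrogen in place of methoxy on an aromatic carbon, this assay gives a 1.8-fold higher number from compound 2 to compound 3 (0.25 log units; within the scatter) and so shows no effect that can be read from removing methoxy at this position of the shared core. Going by these compounds alone, the first pair of measured compounds differing in one place on the other side of the molecule, with diisopropylamino in place of piperidin-1-yl on a thiocarbonyl carbon, gives a 1.1-fold higher number from compound 1 to compound 3 (0.05 log units; within the scatter) and likewise does not separate these two groups in this read-out. No further information bears on these results.

The compounds shown leave open whether a different group at the aromatic carbon, such as chlorine, hydroxy or nitro, would give a step beyond the scatter. They also leave open whether another amine on the thiocarbonyl carbon, such as morpholin-4-yl or dimethylamino, would do so.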